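The source may report more compounds than this note shows. Statements on the series, on what has been measured and on what is new or still open speak of the compounds shown alone.

Compound 1 `O=C1NC(=O)/C(=C/C(c2ccc(-c3ccc4cccc(F)c4c3)[nH]c2=O)C2CC2)O1`: > 3 h
Compound 2 `CC(C)[C@@H](c1ccc(-c2ccc3cccc(F)c3c2)[nH]c1=O)[C@H]1OC(=O)NC1=O`: 1.93 h
Compound 3 `CC(C)C(c1ccc(-c2ccc3cccc(F)c3c2)[nH]c1=O)C1C(=O)NC(=O)N1C`: 0.263 h

All three compounds were tested in an ADME assay on microsomes from liver (Rattus norvegicus) for metabolic stability; a lower number here means that the compound disappears faster, a higher number that the compound lasts longer. Compound 1 gives > 3 h in this assay, and that is a limit of the assay rather than a number. Compound 1 thus stands at the limit of > 3 h in this assay, at which 1 of the 3 values shown sits, the only one of the three to do so. Among the compounds with values here, compound 2 gives 1.93 h and compound 3 gives 0.263 h; these two numbers lie far apart, but no single-change step connects them to each other or to compound 1, so their difference is simply recorded here.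

Compound 4 `O=C1NC(=O)/C(=C/C(Cc2ccccc2)c2ccc(-c3ccc4cccc(F)c4c3)[nH]c2=O)O1` has not yet been measured. It differs from compound 1 in one place: benzyl in place of cyclopropyl on a saturated chain carbon bound to an aromatic carbon and a double-bonded chain carbon. Compound 1 is known only as a limit, and the step to compound 4 has no fixed starting number to be measured against. Nothing among the three measured compounds shows what a benzyl in place of a cyclopropyl does here. The step of an at least 1.5-fold lower number from compound 1 to compound 4 (0.17 log units; that floor lies within the scatter) is expected to be a modest shortening of half-life, of a size that may or may not exceed the usual scatter. Compound 4 is estimated at 2 h, with a range from 0.7 h to 5 h.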

Compound 4, half-life: 2.96 h
Estimate against measurement, compound 4: 1.5-fold (0.17 log units) below, and the stated range covers the measured number.
By their numbers in this assay, from the lowest: compound 3; then compounds 2 and 4 (each within the scatter of the next). At a limit, above all of these: compound 1.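

In this assay, benzyl in place of cyclopropyl on a saturated chain carbon bound to an aromatic carbon and a double-bonded chain carbon gives an at least 1.0-fold lower number from compound 1 to compound 4 (0.00 log units; that floor lies within the scatter). This is the first pair shown that differs in only one place, so it gives the first direct look at this position: a benzyl, with 7 heavy atoms and an aromatic ring, stands where a cyclopropyl with 3 heavy atoms stood, and no real shortening of half-life can be established from this step. Compound 1 is held at a limit of the assay rather than a number, so the true size of the step cannot be fixed: the limit of > 3 h in this assay, at which 1 of the 4 values shown sits.

The compounds shown leave open how a longer chain such as butyl, or a benzyl carrying an amine on its ring, would fare at this same position. They also leave open whether benzyl in place of cyclopropyl would read the same way on the core of compound 2 or the core of compound 3, where the chain carbon is bound to a different ring.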